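Where a sulfonamide replaces two methyls on the pendant phenyl

The source may report more compounds than this note shows. Statements on the series, on what has been measured and on what is new or still open speak of the compounds shown alone.

Measured so far:
compound 1 `CCCS(=O)(=O)Nc1ccc(F)c(C(=O)c2n[nH]c3ncc(-c4cccc(N)c4)cc23)c1F` — 1.6%
compound 2 `CCCS(=O)(=O)Nc1ccc(F)c(C(=O)c2n[nH]c3ncc(-c4ccc(C)c(C)c4)cc23)c1F` — 20%

Both compounds share one core and differ only in the group on the aromatic carbon of that core. In an assay for binding affinity to dual specificity mitogen-activated protein kinase kinase 4 (Homo sapiens), read by KINOMEscan, tested at 100 nM (a lower number here means a stronger effect, a higher number a weaker effect of the compound at the concentration tested), compound 1 gives 1.6%, while compound 2 gives 20%. Going by the values given here, compound 2 therefore stands highest of the two numbers; its only neighbour is compound 1, and the step of a number 18.4 percentage points higher from compound 1 to compound 2 (beyond the scatter) lies beyond the scatter.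

Compound 3 `CCCS(=O)(=O)Nc1ccc(F)c(C(=O)c2n[nH]c3ncc(-c4ccc(NS(C)(=O)=O)cc4)cc23)c1F` has not yet been measured. Its change from compound 2 is 4-(methanesulfonamido)phenyl in place of 3,4-dimethylphenyl on an aromatic carbon.

Among the compounds with values here, only one measured step bears on this change, namely a number 18.4 percentage points higher from compound 1 to compound 2 (beyond the scatter). That step ran from a group with a hydrogen-bond donor to one with none, and the new group of compound 3 again carries a donor and acceptors, though at a different position and with a different substituent. Within the data shown here, the sole comparison therefore points to a lower number for compound 3, of a size comparable to that step, but with wide uncertainty. Compound 3 is expected to give 8% in this assay, within 1% to 35%, a step of a number 12 percentage points lower from compound 2 to compound 3 (beyond the scatter).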

Compound 3, a percentage reported as activity, at one concentration (the size of the read-out at that concentration, not a potency): 0.85%
The estimate for compound 3 lay 7.2 percentage points above the measured number, outside the stated range (below it).
By their numbers in this assay, from the lowest: compounds 3 and 1 (each within the scatter of the next); then compound 2.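

Replacing 3,4-dimethylphenyl with 4-(methanesulfonamido)phenyl on the aromatic carbon of the shared core gives, in this assay, a number 19.2 percentage points lower from compound 2 to compound 3 (beyond the scatter), so the high number of compound 2 now stands against two neighbours rather than one. The 3-aminophenyl and 4-(methanesulfonamido)phenyl groups cannot be told apart at the concentration tested, with a number 0.8 percentage points lower from compound 1 to compound 3 (within the scatter), which shows that two groups differing in their substituent and in where it sits on the phenyl ring can read alike at this position. Among these three compounds, the two groups with a hydrogen-bond donor give the low numbers and the group with none gives the high one, with no compound going against this pattern, but nothing measured here explains it.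

A plain phenyl, a 4-methoxyphenyl or a 4-(N-methyl-methanesulfonamido)phenyl group would test whether the donor matters at all, since the methyl groups of compound 2 differ from the other two groups in more than that one feature. A 3-(methanesulfonamido)phenyl or 4-aminophenyl group would separate the effect of the substituent from that of its place on the ring.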